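The source may hold more compounds than are shown below. What is called first, only, known or untested is meant among the compounds shown, and "the series" means these compounds.

Series notes. Compound 3 `Cc1ccc2cccc(NC(=O)c3cnccn3)c2n1` carries a methyl on the shared core; in a functional assay on PANC-1 cells (Homo sapiens) for inhibition, read by MTT assay, with a stated time of 72 h (on this read-out higher numbers stand for weaker inhibition and lower numbers for stronger inhibition), compound 3 gives > 10000 nM, which is a limit of the assay and not a number. Compound 1 `Cc1cnc(C(=O)Nc2cccc3ccc(C)nc23)cn1` likewise reaches only a limit in this assay, at > 10000 nM. Among the compounds with values here, the one measured step joining them, a step that the two limits leave unreadable from compound 1 to compound 3, is accordingly unreadable. Within the data shown here, compound 2 `Cc1cnc(C(=O)Nc2cc(Cl)cc3cccnc23)cn1` is the sole member with a measured number, giving 1770 nM in this assay. Compound 4 `CN(C)Cc1ccc2cccc(NC(=O)c3cnccn3)c2n1` differs from compound 3 by dimethylamino in place of hydrogen on a saturated chain carbon bound to an aromatic carbon, namely methyl to (dimethylamino)methyl. Among the measured compounds shown here, no measured step bears on this change, and the limit of > 10000 nM in this assay, at which 2 of the 3 values shown sit, leaves the starting point without a number, so no direction can be read. Compound 4 is expected near 8000 nM, within 2000 nM to 30000 nM. The estimated step of an at least 1.2-fold lower number from compound 3 to compound 4 (0.09 log units; that floor lies within the scatter) rests mainly on compound 3 standing at a limit in this assay.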

Compound 4, half-maximal inhibitory concentration: > 10000 nM
Compound 4 was reported as a limit (the forecaster's own chance of this, stated with the estimate: 50%); at least 1.2-fold (0.09 log units) between middle value and limit.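

No step can be read from compound 3 to compound 4, since both stand at the same limit: the limit of > 10000 nM in this assay, at which 3 of the 4 values shown sit. The compounds shown leave open whether methyl to (dimethylamino)methyl changes inhibition at all.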